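Furan for Methoxyphenyl on the Shared Core

This account rests on a few compounds, and the source may have more. Where it says the series, first, only, none or still open, it means among the compounds named here.

Measured so far:
Compound 1, `CCOC(c1ccc(OC)cc1)c1ccc(C(C)C)cc(=O)c1O`: 0.5 ug/mL
Compound 2, `COc1ccc(C(c2ccc3cccnc3c2O)c2ccc3cccnc3c2O)cc1`: < 0.3 ug/mL

Of the compounds shown here, two have been tested in a functional assay on KB cells (Homo sapiens) for antiproliferative activity; a lower number here means a stronger inhibitor, a higher number a weaker inhibitor. Compound 1 has the structure `CCOC(c1ccc(OC)cc1)c1ccc(C(C)C)cc(=O)c1O` and gives 0.5 ug/mL in this assay. Compound 2, `COc1ccc(C(c2ccc3cccnc3c2O)c2ccc3cccnc3c2O)cc1`, is reported only as a limit of the assay, < 0.3 ug/mL, so its true strength is not known as a number. Of the two values shown, one sits at the limit of < 0.3 ug/mL in this assay, at which 1 of the 2 values shown sits.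

Compound 3, `Oc1c(C(c2ccco2)c2ccc3cccnc3c2O)ccc2cccnc12`, has not yet been measured. It differs from compound 2 in one place: furan-2-yl in place of 4-methoxyphenyl on a saturated chain carbon bound to two aromatic carbons. Among the measured compounds shown here, no measured pair with a single change is available here, so there is no step to learn from. Compound 2 already sits at the limit, and the swap of one aromatic ring for a smaller one at the same place gives no firm ground for a large shift either way. The step from compound 2 to compound 3 is expected to be small, an at least 1.3-fold higher number from compound 2 to compound 3 (0.12 log units; that floor lies within the scatter), possibly within the scatter. Compound 3 is therefore estimated at 0.4 ug/mL, with a likely range from 0.1 ug/mL to 1.5 ug/mL.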

Compound 3, half-maximal inhibitory concentration: < 0.3 ug/mL
Compound 3 was reported as a limit; the forecaster's own chance of this, stated with the estimate: 40%; middle value at least 1.3-fold (0.12 log units) from the limit.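

No size can be read for the swap from compound 2 to compound 3, because both results are limits of the assay and not numbers: the limit of < 0.3 ug/mL in this assay, at which 2 of the 3 values shown sit.

The compounds shown leave open whether furan-2-yl in place of 4-methoxyphenyl changes the strength of the compounds in this assay at all, and if it does, in which direction.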